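The compounds below may be only part of what the source reports. "The series", "measured", "known", "first", "only" and "open" are said of these compounds alone.

Measured compounds:
compound 1, `N#Cc1ccc2[nH]c(-c3ccccc3)cc2c1`: 3340 nM
compound 2, `C#Cc1c(-c2ccccc2)[nH]c2ccccc12`: 1610 nM

Of the compounds shown here, two have been measured in an assay on isolated protein for inhibition of Aromatase (Homo sapiens), read by fluorescence, using NADPH, with a stated time of 30 min; on this read-out lower numbers stand for stronger inhibition and higher numbers for weaker inhibition. Compound 1 gives 3340 nM in this assay, the highest of the two numbers, and so the weaker inhibitor on this read-out. Its nearest neighbour is compound 2, which gives 1610 nM in this assay, a lower number that lies beyond the usual scatter. Among the measured compounds shown here, compound 1 and compound 2 differ in more than one place, so no single structural step between them is defined.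

The next compound, compound 3, `O=[N+]([O-])c1ccc2[nH]c(-c3ccccc3)cc2c1`, is still to be measured in this assay. It differs from compound 1 in one place: nitro in place of cyano on an aromatic carbon. For the measured compounds named here, no measured pair shows this same change, so the expectation for compound 3 rests on compound 1 alone. With nothing to point either way, the step from compound 1 to compound 3 is expected to stay within the scatter, as a 1.1-fold lower number from compound 1 to compound 3 (0.05 log units; within the scatter). Compound 3 is therefore estimated at 3000 nM in this assay, with a range from 1000 nM to 10000 nM.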

Compound 3, half-maximal inhibitory concentration: 9000 nM
Estimate against measurement, compound 3: 3.0-fold (0.48 log units) below; low and high end bracket the measured number.
By their numbers in this assay, from the lowest: compound 2; then compound 1; then compound 3.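

Nitro in place of cyano on this aromatic carbon gives a 2.7-fold higher number from compound 1 to compound 3 (0.43 log units; beyond the scatter) in this assay, the first single-place change that can be read on this read-out. It shows that the position is not indifferent to the group it carries: although the step is modest, the exchange moves the number beyond the scatter towards weaker inhibition, with the entering nitro holding more heavy atoms and more hydrogen-bond acceptors than the cyano it replaces. Nothing at hand bears on what lies behind this difference between the two groups.

Among the compounds shown here, with only this one pair, it remains open whether an amine, a carboxylic acid or a methoxy group on the same aromatic carbon would give a number lower than that of compound 1, or whether the core of compound 1 without any group there would do better or worse than either compound. Going by these compounds, it is also open whether nitro in place of cyano would give a step of similar size and direction on another aromatic carbon of the core.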